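The compounds below may be only part of what the source reports. "The series", "measured", "known", "first", "only" and "open" are said of these compounds alone.

The measured compounds, with their results in a functional assay on MGC-803 cells (Homo sapiens) for antiproliferative activity, read by MTT assay, with a stated time of 72 h; a higher number here means a weaker inhibitor, a lower number a stronger inhibitor:

Compound 1 `CCCSc1nc(Cl)c2c(n1)N(Cc1ccccc1)C(C(=O)N1CCN(Cc3ccccc3)CC1)N2` gives 51200 nM.
Compound 2 `CCCSc1nc(Cl)c2c(n1)N(CC1CCCCC1)C(C(=O)N1CCN(C)CC1)N2` gives > 64000 nM, which is a limit of the assay and not a number.
Compound 3 `CCCSc1nc(Cl)c2c(n1)N(Cc1ccccc1)C(C(=O)NCCC1=CCc3ccccc31)N2` gives 27000 nM.

Compound 2 therefore stands at the edge of what this assay can report: one of the three results sits at that limit (the limit of > 64000 nM in this assay, at which 1 of the 3 values shown sits), and it belongs to compound 2. All three compounds are weak inhibitors, and the numbers for compound 1 and compound 3 lie close to each other.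

Compound 4 `CCCSc1nc(Cl)c2c(n1)N(Cc1ccco1)C(C(=O)N1CCN(C)CC1)N2` differs from compound 2 in one place: furan-2-yl in place of cyclohexyl on a saturated chain carbon bound to a nitrogen on an aromatic ring in a ring. Among the measured compounds shown here, no step between two measured compounds that differ in a single place is available, so nothing measured here sets the size of this change. The expectation is that compound 4 stays a weak inhibitor, with a step of an at least 1.1-fold lower number from compound 2 to compound 4 (0.06 log units; that floor lies within the scatter) that is small and not clearly beyond the scatter. The estimate for compound 4 is 55000 nM, expected to fall between 25000 nM and 130000 nM.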

Compound 4, half-maximal inhibitory concentration: 53800 nM
Beside the measured number, compound 4's estimate is 1.0-fold (0.01 log units) above it; the measured number falls inside the stated range.
By their numbers in this assay, from the lowest: compounds 3, 1 and 4 (each within the scatter of the next). At a limit, above all of these: compound 2.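

Compound 2 holds a limit of the assay and not a number: the limit of > 64000 nM in this assay, at which 1 of the 4 values shown sits. In this assay, compound 4 gives a real number, 53800 nM, and replacing cyclohexyl with furan-2-yl on this saturated chain carbon gives an at least 1.1-fold lower number from compound 2 to compound 4 (0.07 log units; that floor lies within the scatter). That step is a floor and not a measured size, so the change may lie within the scatter or go further, but compound 4 remains a weak inhibitor.

Among the compounds shown here, with only this pair at this position, the ring change and the added oxygen cannot be told apart, and thiophen-2-yl, with sulfur in place of the furan oxygen, would help to separate them. From the compounds shown here alone, it also stays open whether a basic group such as a dimethylaminoethyl chain at this place would give a clearly lower number.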